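Phenyl in Place of Isobutyl on a Saturated Ring Carbon

The source may hold more compounds than are shown below. What is called first, only, known or untested is meant among the compounds shown, and "the series" means these compounds.

Compound 1 `Cc1ccc(S(=O)(=O)N2CCC(Cl)CC2)cc1` reaches only a limit in a functional assay on WiDr cells (Homo sapiens) for antiproliferative activity, read by sulforhodamine B assay, with a stated time of 48 h (a higher number here means a weaker inhibitor of growth, a lower number a stronger inhibitor of growth), > 100000 nM.
Compound 2 `CCCCCCC[C@H]1C[C@H](Cl)CCN1S(=O)(=O)c1ccc(C)cc1` gives 54000 nM in this assay.
Compound 3 `Cc1ccc(S(=O)(=O)N2CCC(Cl)=CC2CC(C)C)cc1` gives 21000 nM in this assay.

Compound 3 holds the lower of the two numbers; the step up to compound 2 lies beyond the scatter, while the value of compound 1 is a limit. Compound 4 `Cc1ccc(S(=O)(=O)N2CCC(Cl)=CC2c2ccccc2)cc1` differs from compound 3 by phenyl in place of isobutyl on a saturated ring carbon. Among the measured compounds shown here, the only measured step, an at least 1.8-fold lower number from compound 1 to compound 2 (0.26 log units; that floor lies within the scatter), concerns a heptyl placed on a saturated ring carbon and begins at a limit (the limit of > 100000 nM in this assay, at which 1 of the 3 values shown sits); no measured step exchanges isobutyl for phenyl. Nothing therefore bears directly on this change, and a shift within the scatter is expected in this assay, so the expected step of a 1.4-fold lower number from compound 3 to compound 4 (0.15 log units; within the scatter) is small. Compound 4 is estimated to give 15000 nM, between 4000 nM and 60000 nM.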

Compound 4, concentration for 50% growth inhibition: 18000 nM
Estimate against measurement, compound 4: 1.2-fold (0.08 log units) below; measured number inside the range.
By their numbers in this assay, from the lowest: compounds 4 and 3 (each within the scatter of the next); then compound 2. At a limit, above all of these: compound 1.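

Phenyl in place of isobutyl on this saturated ring carbon, next to the ring nitrogen, gives a 1.2-fold lower number from compound 3 to compound 4 (0.07 log units; within the scatter) in this assay, so a six-membered aromatic ring stands here with no change beyond the scatter. Unlike the earlier step, which began at a limit, this one joins two measured numbers. Nothing shown accounts for this result.

From the compounds shown here alone, whether an amine or a carboxylic acid on this carbon would move the number beyond the scatter stays open. So does the effect of a longer chain on this same core.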